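The compounds below may be only part of what the source reports. "The series", "measured", "known", "first", "only" and "open" are said of these compounds alone.

Measured in an ADME assay on HEK293 cells (Homo sapiens) for cytotoxicity, read by resazurin assay, with a stated time of 48 h; on this read-out higher numbers stand for lower toxicity in this test and lower numbers for higher toxicity in this test:
compound 1 `Cc1ccccc1S(=O)(=O)Nc1ccc2oc(-c3ccccc3)nc2c1` — 57000 nM
compound 2 `O=S(=O)(Nc1ccc2oc(-c3ccccc3)nc2c1)c1cccc(O)c1` — in this assay compound 2 reaches only a limit, > 100000 nM

Compound 2 therefore stands at the limit of > 100000 nM in this assay, at which 1 of the 2 values shown sits, a limit of the assay rather than a number. Compound 3 `COc1ccc(Cl)cc1S(=O)(=O)Nc1ccc2oc(-c3ccccc3)nc2c1` is not yet measured; the change from compound 2 is 5-chloro-2-methoxyphenyl in place of 3-hydroxyphenyl on a sulfonyl sulfur. For the measured compounds named here, the only step at this position is an at least 1.7-fold higher number from compound 1 to compound 2 (0.24 log units; that floor lies within the scatter), an aryl swap on the sulfonyl sulfur that gave no movement beyond the scatter. The present swap is expected to stay similarly small, so a step of an at least 1.4-fold lower number from compound 2 to compound 3 (0.15 log units; that floor lies within the scatter) of about no direction is estimated. Compound 3 is expected at 70000 nM, with a range of 30000 nM to 160000 nM.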

Compound 3, half-maximal cytotoxic concentration: 74000 nM
Compound 3: middle estimate off by 1.1-fold (0.02 log units), on the low side; low and high end bracket the measured number.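

In this assay, a further aryl group on the sulfonyl sulfur again gives no movement beyond the scatter: a 1.3-fold higher number from compound 1 to compound 3 (0.11 log units; within the scatter). With 5-chloro-2-methoxyphenyl in place of 3-hydroxyphenyl, the step reads an at least 1.3-fold lower number from compound 2 to compound 3 (0.13 log units; that floor lies within the scatter). That step is only a floor, since compound 2 gives a limit and not a number: the limit of > 100000 nM in this assay, at which 1 of the 3 values shown sits.

Still open, as far as these compounds go, is the actual value of compound 2. Also open, from the compounds shown here alone, is whether an amine or a carboxylic acid on this aryl ring, or a longer alkyl chain in its place on the sulfonyl sulfur, would move the number beyond the scatter.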